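Cytotoxicity of Cyclopentane Diol Amides: Expecting a Nitro Analogue

The source may hold more compounds than are shown below. What is called first, only, known or untested is meant among the compounds shown, and "the series" means these compounds.

Compound 1 `CCCCCCOC(=O)/C=C/[C@H]1C[C@@H](O)[C@@H](O)C1`, compound 2 `O=C(/C=C/[C@H]1C[C@@H](O)[C@@H](O)C1)Nc1ccccc1` and compound 3 `Cc1ccc(NC(=O)/C=C/[C@H]2C[C@@H](O)[C@@H](O)C2)cc1` share one core. In an ADME assay on S2 cells (Drosophila melanogaster) for cytotoxicity, read by MTT assay (a higher number here means that more compound is needed for the effect, a lower number that less compound is needed), compound 1 gives > 350000 nM, which is a limit of the assay rather than a number. Compound 2 gives > 200000 nM, also a limit. Compound 3 gives > 190000 nM, again a limit, so compound 3 stands only at a limit, as do the two other values shown. The step that the two limits leave unreadable from compound 2 to compound 3 cannot be sized because both its ends are limits (the limit of > 200000 nM in this assay, at which 1 of the 3 values shown sits, and (the limit of > 190000 nM in this assay, at which 1 of the 3 values shown sits)). Compound 4 `O=C(/C=C/[C@H]1C[C@@H](O)[C@@H](O)C1)Nc1ccc([N+](=O)[O-])cc1` differs from compound 3 by nitro in place of methyl on an aromatic carbon. No readable step bears on this change, so no shift beyond the scatter is expected, and a limit is the likeliest outcome. Compound 4 is estimated at 250000 nM. The expected range for compound 4 runs from 100000 nM to 600000 nM. The step thus expected is a step that the limit leaves unreadable from compound 3 to compound 4.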

Compound 4, half-maximal effective concentration: > 170000 nM
Compound 4 gave a limit, no number; the forecaster's own chance of this, stated with the estimate: 85%; the middle value lies beyond the limit too.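

Going by these compounds alone, compound 2, compound 3 and compound 4 all stand at limits of the assay, and no step among them can be read. The compounds shown leave open whether hydrogen, methyl or nitro on the aromatic carbon changes the result in this assay.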